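The source may report more compounds than this note shows. Statements on the series, on what has been measured and on what is new or still open speak of the compounds shown alone.

Series notes. In a functional assay on CCRF-CEM cells (Homo sapiens) for inhibition, read by MTT assay, with a stated time of 2 days, tested at 10 uM (on this read-out lower numbers stand for less inhibition and higher numbers for more inhibition at the one concentration tested (going by the name of the read-out)), compound 1 `COc1cc(OC)cc(-c2cn(-c3ccc(O)c(C(=O)OCCCc4ccccc4)c3)nn2)c1` gives 8% and compound 2 `O=C(OCCCc1ccccc1)c1cc(-n2cc(-c3cc(O)ccc3O)nn2)ccc1O` gives 81%; compound 2 thus stands highest of the two numbers, with compound 1 nearest. Among the compounds with values here, the one measured step, a number 73 percentage points higher from compound 1 to compound 2 (beyond the scatter), bears directly on the next change: compound 3 `COc1ccc(-c2cn(-c3ccc(O)c(C(=O)OCCCc4ccccc4)c3)nn2)cc1` carries 4-methoxyphenyl in place of 2,5-dihydroxyphenyl on an aromatic carbon. The enters group is nearer in kind to the group in compound 1 than to that in compound 2, so a large drop in this assay is expected, partly reversing that step. The expected step is a number 61 percentage points lower from compound 2 to compound 3 (beyond the scatter). Compound 3 is estimated at 20%, range 5% to 50%.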

Compound 3, a percentage reported as inhibition, at one concentration (the size of the read-out at that concentration, not a potency): 5%
Compound 3: the middle estimate sits 15 percentage points above what was measured; the measured number falls inside the stated range.
By their numbers in this assay, from the lowest: compounds 3 and 1 (each within the scatter of the next); then compound 2.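

In this assay the 4-methoxyphenyl group gives a number 76 percentage points lower from compound 2 to compound 3 (beyond the scatter), while against the 3,5-dimethoxyphenyl group it gives a number 3 percentage points lower from compound 1 to compound 3 (within the scatter). On this aromatic carbon of the five-membered ring, the two methoxy-bearing groups therefore read alike, and among these three compounds only the 2,5-dihydroxyphenyl group of compound 2 stands apart. No measurement here accounts for that gap. The compounds shown leave open whether a phenyl group with a single hydroxyl would keep the high number of compound 2. They also leave open how an aminophenyl group would read at this position.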